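The source may report more compounds than this note shows. Statements on the series, on what has been measured and on what is new or still open speak of the compounds shown alone.

Measured compounds in a physicochemical assay for acid dissociation, read by spectrophotometry:
compound 1, `CCc1c(O)c(=O)ccn1CC`: 9.93
compound 2, `CCc1c(O)c(=O)ccn1CCN(C)C`: 9.58

Compound 1 stands highest of the two numbers; its nearest neighbour is compound 2, and the step of a number 0.35 log units lower from compound 1 to compound 2 (beyond the scatter) lies beyond the scatter but counts as modest.

The next compound in the series is compound 3, `CCn1ccc(=O)c(O)c1C(C)O`, not yet measured in this assay. Relative to compound 1 the change is hydroxy in place of hydrogen on a saturated chain carbon bound to an aromatic carbon and a saturated chain carbon; cut one bond further out, it reads as ethyl to 1-hydroxyethyl.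

Among the measured compounds shown here, the only measured step that bears on this is the one from compound 1 to compound 2, where a dimethylamino entered in place of hydrogen on a saturated chain carbon two bonds from an aromatic nitrogen and the number fell by a number 0.35 log units lower from compound 1 to compound 2 (beyond the scatter). The change to compound 3 puts a different group at a different place, so that step is a loose guide at best. The working expectation is a step of about the same size and direction, estimated as a number 0.38 log units lower from compound 1 to compound 3 (beyond the scatter). For compound 3 the expected value in this assay is 9.55, with a range from 9.2 to 9.9.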

Compound 3, acid dissociation constant: 8.77
Beside the measured number, compound 3's estimate is 0.78 log units above it, outside the stated range (below it).
By their numbers in this assay, from the lowest: compound 3; then compound 2; then compound 1.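

In this assay, hydroxy in place of hydrogen on a saturated chain carbon bound to an aromatic carbon and a saturated chain carbon, the change from ethyl to 1-hydroxyethyl, gives a number 1.16 log units lower from compound 1 to compound 3 (beyond the scatter). Among the compounds shown here, the series therefore holds a large step for a single added oxygen at this carbon, whereas the only earlier step, a number 0.35 log units lower from compound 1 to compound 2 (beyond the scatter), was modest and came from a dimethylamino at a different place, so that step did not show how far the number can move across these compounds. No measurement shown here accounts for the size of the new step.

The compounds shown leave open whether this step belongs to the hydroxy itself or would also appear with another group on the same chain carbon, such as a methoxy or an amine. They also leave open whether a longer chain carrying the hydroxy, or a hydroxymethyl in place of the 1-hydroxyethyl, would keep a step of this size in this assay.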